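Adding a methylimidazolyl ring to a tetrazole with low oral bioavailability

A few compounds are considered here, and "the series" means these few. Any claim that something is new, unique, unknown or untested is made for them only; others in the source may bear on it.

Measured compounds:
compound 1 `CCCCN(c1nc2ccccc2o1)[C@H](C)c1ccc(-c2ccccc2-c2nnn[nH]2)cc1`: 1.8%
compound 2 `C[C@H](c1ccc(-c2ccccc2-c2nc(=O)o[nH]2)cc1)N(CC1CC1)c1nc2c(C(=O)O)cccc2o1`: 60%

In an ADME assay on the whole organism (Macaca fascicularis) for pharmacokinetics, read by LC-MS, using cassette dosing (on this read-out lower numbers stand for lower oral bioavailability and higher numbers for higher oral bioavailability), compound 1 gives 1.8%, the lower of the two numbers shown. For the measured compounds named here, compound 2 differs from compound 1 in several places at once, and in this assay compound 2 gives 60%, a gap beyond the usual scatter; no single step connects the two, so their values can only be set side by side.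

Compound 3 `CCCCN(c1nc2c(-c3nccn3C)cccc2o1)[C@H](C)c1ccc(-c2ccccc2-c2nnn[nH]2)cc1` differs from compound 1 in one place: 1-methyl-1H-imidazol-2-yl in place of hydrogen on an aromatic carbon. Going by the values given here, no measured pair shows the effect of this exact change in this assay. Given that compound 1 sits at 1.8%, the author expects the step from compound 1 to compound 3 to be small, most likely upward, and possibly not beyond the scatter: a number 8.2 percentage points higher from compound 1 to compound 3 (within the scatter). Compound 3 is therefore estimated at 10% in this assay, within a range from 1% to 35%.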

Compound 3, oral bioavailability: 7.5%
The estimate for compound 3 lay 2.5 percentage points above the measured number, and the stated range covers the measured number.
By their numbers in this assay, from the lowest: compounds 1 and 3 (each within the scatter of the next); then compound 2.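

In this assay, 1-methyl-1H-imidazol-2-yl in place of hydrogen on an aromatic carbon gives a number 5.7 percentage points higher from compound 1 to compound 3 (within the scatter), the first single-place step available in this series. It shows that this change at this position, ortho to a fused ring and meta to a fused ring, does not by itself move the core of compound 1 beyond the scatter. It therefore does not connect compound 1 with the much higher number of compound 2. Nothing at hand accounts for the size of this step.

Still open, on these data alone, is whether an amine or a primary amide on the same aromatic carbon would give a step beyond the scatter. Also open, as far as these compounds go, is whether the 1-methyl-1H-imidazol-2-yl group would give a similar step if a longer chain stood on the core of compound 1.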